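The source may hold more compounds than are shown below. What is called first, only, known or untested is meant among the compounds shown, and "the series" means these compounds.

Measured in a functional assay on SEM cells (Homo sapiens) for cytotoxicity, with a stated time of 72 h; a lower number here means that less compound is needed, a higher number that more compound is needed for the effect:
Compound 1 `C=C[C@@](C)(/C=C/c1ccc(OCc2ccccc2)cc1)CCC=C(C)C`: > 36600 nM
Compound 2 `C=C[C@@](C)(/C=C/c1ccc(O)c(/C=C/C(=O)c2ccccc2)c1)CCC=C(C)C`: 8000 nM
Compound 3 `CC(C)=CCC[C@@](C)(/C=C/c1ccccc1)/C=C/c1ccc(O)cc1`: > 36600 nM

Compound 1 has no exact value, because its result of > 36600 nM is a limit of this assay and not a number. Compound 3 gives > 36600 nM, which is also a limit. The picture so far is therefore mostly (the limit of > 36600 nM in this assay, at which 2 of the 3 values shown sit). Among the measured compounds shown here, compound 2 is the only one with a true number, at 8000 nM.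

The next compound to be tested is compound 4 `C=C[C@@](C)(/C=C/c1ccc(Nc2ccc(OC)cc2)cc1)CCC=C(C)C`, which keeps the core of compound 1 and changes one group. It has (4-methoxyphenyl)amino in place of benzyloxy on an aromatic carbon, para to a large group ((4-methoxyphenyl)amino in place of benzyloxy on an aromatic carbon).

For the measured compounds named here, no measured pair of compounds shows a change of this kind, so any forecast is loose. A small shift towards a lower number is expected, and a result within the usual scatter would be no surprise. This expectation leans on compound 1, which carries benzyloxy at this place and gives > 36600 nM, a limit. The expected change is an at least 1.4-fold lower number from compound 1 to compound 4 (0.16 log units; that floor lies within the scatter), and it starts from a limit, so its size is uncertain. Compound 4 is estimated at 25000 nM, within an expected range from 8000 nM to 60000 nM.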

Compound 4, half-maximal effective concentration: > 36600 nM
Compound 4: no number, only a limit (the forecaster's own chance of this, stated with the estimate: 55%); middle value at least 1.4-fold (0.16 log units) away from the limit.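

In this assay compound 4 gives > 36600 nM, which is a limit and not a number. Compound 1 also sits at a limit, so no step can be read between compound 1 and compound 4. The compounds shown leave open whether (4-methoxyphenyl)amino in place of benzyloxy changes the result at all, and by how much.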